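The source may hold more compounds than are shown below. What is called first, only, known or untested is meant among the compounds shown, and "the series" means these compounds.

In an ADME assay (liver) for metabolic stability, with Liver microsome (Homo sapiens) as the target, using microsomes and NADPH, with a stated time of 30 min, tested at 1 uM (on this read-out higher numbers stand for fast clearance and lower numbers for slow clearance), compound 1 `COc1cc(C(O)(C(F)(F)F)C(F)(F)F)cnc1N1CCN(S(=O)(=O)c2ccc(N)nc2)CC1` gives < 14 mL.min-1.g-1, which is a limit of the assay and not a number. Compound 2 `CC(C)n1cc(-c2cc(C(O)(C(F)(F)F)C(F)(F)F)cnc2N2CCN(S(=O)(=O)c3ccc(N)nc3)CC2)cn1` gives 38 mL.min-1.g-1, and compound 3 `Nc1ccc(S(=O)(=O)N2CCN(c3ncc(C(O)(C(F)(F)F)C(F)(F)F)cc3-c3ccc4sccc4c3)CC2)cn1` gives 48 mL.min-1.g-1; these two numbers sit within the scatter of each other. Compound 4 `Nc1ccc(S(=O)(=O)N2CCN(c3ncc(C(O)(C(F)(F)F)C(F)(F)F)cc3-c3ccc4scnc4c3)CC2)cn1` carries 1,3-benzothiazol-5-yl in place of 1-benzothiophen-5-yl on an aromatic carbon. Replacing methoxy moved the number clearly, an at least 2.7-fold higher number from compound 1 to compound 2 (0.43 log units; beyond the scatter) and an at least 3.4-fold higher number from compound 1 to compound 3 (0.53 log units; beyond the scatter), but that is a different kind of exchange. The closer guide swaps one aromatic group for another, and a 1.3-fold higher number from compound 2 to compound 3 (0.10 log units; within the scatter) stayed within the scatter. The expected step is therefore small, a 1.2-fold lower number from compound 3 to compound 4 (0.08 log units; within the scatter), and not beyond the scatter. Compound 4 is estimated at 40 mL.min-1.g-1, with an expected range from 22 mL.min-1.g-1 to 72 mL.min-1.g-1.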

Compound 4, intrinsic clearance in microsomes: 39 mL.min-1.g-1
Compound 4: the middle estimate sits 1.0-fold (0.01 log units) above what was measured; measured number inside the range.
By their numbers in this assay, from the lowest: compounds 2, 4 and 3 (each within the scatter of the next). At a limit, below all of these: compound 1.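

In this assay, the ring nitrogen that 1,3-benzothiazol-5-yl brings to the five-membered ring makes no readable difference, with a 1.2-fold lower number from compound 3 to compound 4 (0.09 log units; within the scatter), and swapping in this group for 1-isopropyl-1H-pyrazol-4-yl also makes none, with a 1.0-fold higher number from compound 2 to compound 4 (0.01 log units; within the scatter). Methoxy remains the one clear contrast at this position, with an at least 2.7-fold higher number from compound 1 to compound 4 (0.44 log units; beyond the scatter). That step is only a bound, as compound 1 gives a limit of the assay and not a number: the limit of < 14 mL.min-1.g-1 in this assay, at which 1 of the 4 values shown sits.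

As far as these compounds go, whether an amine or a short alkyl chain at this place would behave like methoxy or like the aromatic groups stays open.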